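This account rests on a few compounds, and the source may have more. Where it says the series, first, only, none or still open, it means among the compounds named here.

Compound 1 `O=C1/C(=C/c2ccccc2F)CN(S(=O)(=O)c2ccc(Cl)cc2)C/C1=C\c1ccccc1F` carries two fluorophenyl arms on the shared core and a (4-chlorophenyl)sulfonyl group on the ring nitrogen. In a functional assay on SMMC-7721 cells (Homo sapiens) for cytotoxicity, read by MTT assay, with a stated time of 24 h (a lower number here means a stronger inhibitor, a higher number a weaker inhibitor), compound 1 gives 4500 nM. Compound 2 `O=C1/C(=C/c2ccccc2F)CN(S(=O)(=O)c2ccc(Br)cc2)C/C1=C\c1ccccc1F` differs from it only by bromo in place of chloro on an aromatic carbon, and in this assay compound 2 gives 5200 nM; the step of a 1.2-fold higher number from compound 1 to compound 2 (0.06 log units; within the scatter) is small. Compound 3 `O=C1/C(=C/c2cccc(F)c2)CN(S(=O)(=O)c2ccc(Cl)cc2)C/C1=C\c1cccc(F)c1` keeps the (4-chlorophenyl)sulfonyl group but has the same atoms as compound 1 joined differently; the difference between the two cores is not broken down here. In this assay compound 3 gives 7800 nM, and its gaps to compound 1 and compound 2 are both within the scatter, so no order among the three is claimed.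

Compound 4 `O=C1/C(=C/c2cccc(F)c2)CN(S(=O)(=O)c2ccc(Br)cc2)C/C1=C\c1cccc(F)c1` is not yet measured. It stands to compound 3 as compound 2 stands to compound 1: the change is bromo in place of chloro on an aromatic carbon, at the same place in both pairs. Because a 1.2-fold higher number from compound 1 to compound 2 (0.06 log units; within the scatter) was small, the expected step of a 1.2-fold higher number from compound 3 to compound 4 (0.06 log units; within the scatter) is likewise small. Compound 4 is therefore estimated at 9000 nM in this assay, with the expected range 4500 nM to 18000 nM.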

Compound 4, half-maximal inhibitory concentration: 11700 nM
For compound 4 the middle estimate is 1.3-fold (0.11 log units) below the measured one, within the range that was stated.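

Bromo in place of chloro on an aromatic carbon gives a 1.5-fold higher number from compound 3 to compound 4 (0.18 log units; within the scatter) in this assay. Set beside the earlier pair, the change shows no detectable difference between the two cores: the same change on two cores in this assay, a 1.2-fold higher number (0.06 log units; within the scatter) from compound 1 to compound 2 and a 1.5-fold higher number (0.18 log units; within the scatter) from compound 3 to compound 4, 1.3-fold (0.11 log units) apart, within the scatter of two such steps. This shows that, in these two pairs, the exchange stays within the scatter on either core; it does not show that the two steps are identical, that the bromo compounds differ from their chloro partners, or that the same would hold on any further core.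

The compounds shown leave open whether a group other than a halogen at the same place on the aromatic ring, such as an amine, a carboxylic acid or a longer alkoxy chain, would give a step beyond the scatter. On these data alone, all four compounds carry fluorophenyl arms, so it also remains open whether the step would carry over to arms bearing a nitrile or a methoxy group in place of fluoro.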